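Methoxy to hydroxy on the saturated carbon of compound 1

A few compounds are considered here, and "the series" means these few. Any claim that something is new, unique, unknown or untested is made for them only; others in the source may bear on it.

Among the measured compounds shown here, compound 1 `CO[C@]1(c2ccc(OCc3c(-c4c(Cl)cccc4Cl)noc3C3CC3)cc2Cl)C[C@H](c2cccc(C(=O)O)c2)C1` is one of two compounds measured in an assay on isolated protein for agonist activity at Bile acid receptor (Homo sapiens), read by FRET; a higher number here means that more compound is needed for the effect, a lower number that less compound is needed. In this assay compound 1 gives 79 nM, the higher of the two numbers. Compound 2 `CC(C)n1nc(C(=O)O)cc1[C@@H]1C[C@H]1c1ccc(OCc2c(-c3c(Cl)cccc3Cl)noc2C2CC2)cc1Cl` gives 4 nM, lower than the number for compound 1 by more than the usual scatter. For the measured compounds named here, no pair of measured compounds differing in a single place is available, so the series gives no direct guide for the change now considered. Compound 3 `O=C(O)c1cccc([C@H]2C[C@](O)(c3ccc(OCc4c(-c5c(Cl)cccc5Cl)noc4C4CC4)cc3Cl)C2)c1` differs from compound 1 in one place: hydrogen in place of methyl on an oxygen on a saturated carbon. Read one bond further out, methoxy becomes hydroxy. With no measured step of this kind in the series, the expected step in this assay is small, and a modestly higher number is expected, which is a 1.4-fold higher number from compound 1 to compound 3 (0.14 log units; within the scatter). Compound 3 is therefore expected to give 110 nM in this assay, within a range of 40 nM to 300 nM.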

Compound 3, half-maximal effective concentration: 29 nM
Beside the measured number, compound 3's estimate is 3.8-fold (0.58 log units) above it, and the stated range ends above it.
By their numbers in this assay, from the lowest: compound 2; then compound 3; then compound 1.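

Among the compounds shown here, this gives the first single-place step: methoxy to hydroxy on the saturated carbon gives a 2.7-fold lower number from compound 1 to compound 3 (0.44 log units; beyond the scatter) in this assay. The methyl on this oxygen is therefore not required for activity here, and removing it lowers the number needed for the effect, modestly but beyond the scatter. No available measurement bears on the origin of this step.

On these data alone, whether the oxygen itself is needed on this saturated carbon remains open, and an amine or a fluorine atom there would test it. A single step also leaves the effect of size on this oxygen undefined, and an ethoxy group or a longer chain would show whether the number rises further as the group grows from hydrogen through methyl.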